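The compounds below may be only part of what the source reports. "The series", "measured", "known", "first", "only" and "open" are said of these compounds alone.

Compound 1 `COc1cccc(Oc2ccc(CN3C(=O)C(=O)c4cc(OC(F)(F)F)ccc43)cc2)n1` gives 51% in a functional assay on CHO cells for positive allosteric modulation of muscarinic acetylcholine receptor M5 (Homo sapiens), read by FLIPR and calcium flux, with a stated time of 1 h; a lower number here means a smaller maximal response, a higher number a larger maximal response.
Compound 2 `O=C1C(=O)N(Cc2ccc(Oc3nccs3)cc2)c2ccc(OC(F)(F)F)cc21` gives 58% in this assay.
Compound 3 `O=C1C(=O)N(Cc2ccc(Oc3cccc(F)n3)cc2)c2ccc(OC(F)(F)F)cc21` is not yet measured.

Compound 2 sits at the top of the two numbers, a position the scatter does not separate from compound 1. For the measured compounds named here, the only measured step, a number 7 percentage points higher from compound 1 to compound 2 (within the scatter), lies within the scatter. Compound 3 differs from compound 2 by 6-fluoropyridin-2-yl in place of 1,3-thiazol-2-yl on an oxygen on an aromatic ring. The entering six-membered aromatic ring resembles that of compound 1, whose step to compound 2 was within the scatter, so no change beyond the scatter is expected; the expected step is a number 3 percentage points lower from compound 2 to compound 3 (within the scatter). Compound 3 is estimated at 55%, within 40% to 70%.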

Compound 3, largest response reached (Emax), in percent of the reference or control that the assay uses: 62%
Estimate against measurement, compound 3: 7 percentage points below; the measured number falls inside the stated range.
By their numbers in this assay, from the lowest: compounds 1, 2 and 3 (each within the scatter of the next, the first and the last beyond it).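

In this assay the change on an oxygen on an aromatic ring gives a number 4 percentage points higher from compound 2 to compound 3 (within the scatter) and so does not separate 6-fluoropyridin-2-yl from 1,3-thiazol-2-yl. Fluoro in place of methoxy on an aromatic carbon gives a number 11 percentage points higher from compound 1 to compound 3 (beyond the scatter) and is the first step in the series to pass the scatter, though only modestly. Nothing measured here speaks to the reason for either step. Open, from the compounds shown here alone, is how a methyl, a chloro or a dimethylamino group in place of the fluoro would read, and whether the step from methoxy to fluoro carries over to other rings on that oxygen.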